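The source may report more compounds than this note shows. Statements on the series, on what has been measured and on what is new or still open speak of the compounds shown alone.

Among the measured compounds shown here, compound 1 `COc1cc(/C=C/C(=O)Nc2ccc(NC(=O)[C@@H](O)[C@H](N)CCc3ccccc3)cc2)cc(OC)c1OC` gives 850 nM in a functional assay on HUVEC cells (Homo sapiens) for antiproliferative activity (on this read-out higher numbers stand for weaker inhibition of growth and lower numbers for stronger inhibition of growth), the lowest of the two numbers known so far. Its nearest neighbour, compound 2 `CCOc1ccc(/C=C/C(=O)Nc2ccc(NC(=O)[C@@H](O)[C@H](N)CCc3ccccc3)cc2)cc1`, gives 1800 nM in this assay. For the measured compounds named here, the single measured step, a 2.1-fold higher number from compound 1 to compound 2 (0.33 log units; beyond the scatter), comes from a 4-ethoxyphenyl in place of a 3,4,5-trimethoxyphenyl on a double-bonded chain carbon bound to a double-bonded chain carbon, a change at the far end of the molecule.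

Compound 3 `COc1cc(NC(=O)/C=C/c2cc(OC)c(OC)c(OC)c2)ccc1NC(=O)[C@@H](O)[C@H](N)CCc1ccccc1` differs from compound 1 in another place: methoxy in place of hydrogen on an aromatic carbon. The new group sits on an aromatic carbon of a six-membered aromatic ring of carbon only, ortho to a large group and meta to a large group. Going by the values given here, no measured step touches this part of the shared core, so the step from compound 1 to compound 2 gives no direct guide, and the added methoxy is a small change. No step beyond the scatter is therefore expected in this assay; the expected step is a 1.1-fold higher number from compound 1 to compound 3 (0.02 log units; within the scatter). Compound 3 is thus estimated to give about 900 nM, within a range from 300 nM to 2700 nM.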

Compound 3, concentration for 50% growth inhibition: 700 nM
Compound 3: the middle estimate sits 1.3-fold (0.11 log units) above what was measured; measured number inside the range.
By their numbers in this assay, from the lowest: compounds 3 and 1 (each within the scatter of the next); then compound 2.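

In this assay, methoxy in place of hydrogen on an aromatic carbon, ortho to a large group and meta to a large group, gives a 1.2-fold lower number from compound 1 to compound 3 (0.08 log units; within the scatter), so compound 1 and compound 3 cannot be told apart on this read-out. Among the compounds shown here, this is the first measured change to the shared core rather than to the far end of the molecule, where the one earlier change gave a 2.1-fold higher number from compound 1 to compound 2 (0.33 log units; beyond the scatter), and it shows that this aromatic carbon can carry methoxy, with its two heavy atoms, without a step beyond the scatter. Nothing further bears on this result, so the data show only the size of the step and offer no account of it.

The compounds shown leave open whether this place would accept something other than methoxy, such as an amine, a carboxylic acid or a longer alkoxy chain like butoxy, with the same small step. They also leave open whether methoxy here would give a similar step when the 3,4,5-trimethoxyphenyl is replaced by the 4-ethoxyphenyl of compound 2.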